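The compounds below may be only part of what the source reports. "The series", "measured", "known", "first", "only" and "open" are said of these compounds alone.

In an ADME assay on Vero cells (Chlorocebus sabaeus) for cytotoxicity, read by resazurin assay, with a stated time of 3 days (on this read-out higher numbers stand for weaker inhibition and lower numbers for stronger inhibition), compound 1 `CN(C)c1cc2[nH]c(C3CCCCC3)nc2cc1NC(=O)c1cccs1` sits at the limit of > 100 ug/mL, a limit of the assay and not a number. Compound 2 `CCN(CC)c1cc2[nH]c(C3CCCCC3)nc2cc1NC(=O)NCc1ccccc1` likewise gives the limit of > 100 ug/mL in this assay. Compound 3 `CCCNC(=O)Nc1cc2nc(C3CCCCC3)[nH]c2cc1N(CC)CC` also gives the limit of > 100 ug/mL in this assay. Within the data shown here, the only single change among the measured pairs, a step that the two limits leave unreadable from compound 2 to compound 3, cannot be read, because the limit of > 100 ug/mL in this assay, at which 3 of the 3 values shown sit, leaves every measured value at the same limit. Compound 4 `Cc1ccc(C(=O)Nc2cc3nc(C4CCCCC4)[nH]c3cc2N(C)C)cc1` differs from compound 1 by 4-methylphenyl in place of thiophen-2-yl on a carbonyl carbon. Among the measured compounds shown here, no measured step bears directly on this change, so no shift beyond the scatter is expected, and the step that the limit leaves unreadable from compound 1 to compound 4 is an estimate only. Compound 4 is estimated at 150 ug/mL, within 60 ug/mL to 400 ug/mL in this assay.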

Compound 4, half-maximal inhibitory concentration: > 100 ug/mL
Compound 4: a limit, no number; the forecaster's own chance of this, stated with the estimate: 85%; the middle value is on the limit's open side.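

No step can be read from compound 1 to compound 4, because both sit at a limit of the assay and not at a number: the limit of > 100 ug/mL in this assay, at which 4 of the 4 values shown sit. Whether any of these changes shifts the result in this assay stays open, with no compound shown giving a number.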